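A few compounds are considered here, and "the series" means these few. Any claim that something is new, unique, unknown or untested is made for them only; others in the source may bear on it.

Of the compounds shown here, two have been measured in an assay on HEK293 cells for antagonist activity at P2X purinoceptor 7 (Homo sapiens), read by fluorescence, with a stated time of 2 h; a lower number here means a stronger inhibitor, a higher number a weaker inhibitor. Compound 1, `O=C(Oc1ccc(-c2cncn2C2CCN(C(=O)c3ccc(Cl)c(C(F)(F)F)c3)CC2)cc1)c1ccccc1`, gives only a limit in this assay: > 10000 nM. Compound 2, `O=C(c1ccc(Oc2ccccc2)cc1)N1CCC(n2cncc2-c2ccc(OS(=O)(=O)c3cccc4cnccc34)cc2)CC1`, gives 187 nM in this assay. For the measured compounds named here, this is the only actual number among the two values, since compound 1 sits at the limit (the limit of > 10000 nM in this assay, at which 1 of the 2 values shown sits). Compound 3, `CCN(CC)c1ccc(C(=O)N2CCC(n3cncc3-c3ccc(OS(=O)(=O)c4cccc5cnccc45)cc3)CC2)cc1`, differs from compound 2 in one place: diethylamino in place of phenoxy on an aromatic carbon. Going by the values given here, no measured pair shows what such a change does, so the expectation rests on compound 2 alone and on the counted difference, which swaps a ring-bearing group for a shorter chain group without a ring. A modest loss of potency is expected from compound 2 to compound 3, about a 2.1-fold higher number from compound 2 to compound 3 (0.33 log units; beyond the scatter), somewhat beyond the usual scatter. Compound 3 is therefore estimated at 400 nM in this assay, with a likely range from 120 nM to 1500 nM.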

Compound 3, half-maximal inhibitory concentration: 1440 nM
For compound 3 the middle estimate is 3.6-fold (0.56 log units) below the measured one, and the stated range covers the measured number.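

Replacing phenoxy with diethylamino gives a 7.7-fold higher number from compound 2 to compound 3 (0.89 log units; beyond the scatter) in this assay, the first measured sign that the group on this aromatic carbon, para to a large group, has a clear bearing on inhibitor strength. Compound 3 still gives a real number rather than a limit, so a six-membered aromatic ring at this place is not required for measurable inhibition, although compound 2, which carries one, is the stronger of the pair. For the compounds shown here, nothing measured so far explains the size of this step.

The compounds shown leave open whether the ring, the oxygen that links it or the nitrogen that enters accounts for the step. An anilino group or a cyclohexyloxy group at this place would help separate these, and a piperidine ring would show whether tying the diethylamino chains into a ring changes the number.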